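Selenium to sulfur on the amidine-type carbon of compound 1

This account rests on a few compounds, and the source may have more. Where it says the series, first, only, none or still open, it means among the compounds named here.

Compound 1 `C[Se]/C(=N\C(=O)c1cc2ccccc2s1)NC(=O)c1cc2ccccc2s1` is measured in a functional assay on HepG2 cells (Homo sapiens) for cytotoxicity, read by MTT assay, with a stated time of 72 h (on this read-out higher numbers stand for weaker inhibition of growth and lower numbers for stronger inhibition of growth), at 9590 nM. Among the two numbers in this assay it is the highest; compound 3 `C[Se]/C(=N\C(=O)c1cnc2ccccc2c1)NC(=O)c1cnc2ccccc2c1` gives 4160 nM, and the gap between these two values lies beyond the scatter. Compound 2 `CS/C(=N\C(=O)c1ccno1)NC(=O)c1ccno1` gives only a limit of this assay, > 100000 nM. Compound 4 `CS/C(=N\C(=O)c1cc2ccccc2s1)NC(=O)c1cc2ccccc2s1` differs from compound 1 by a group of 2 heavy atoms (1 carbon, 1 sulfur; no ring) in place of a group of 2 heavy atoms (1 carbon, 1 selenium; no ring), on a carbon with a double bond to nitrogen. For the measured compounds named here, no step between measured compounds covers this change, so its size is open from the data at hand. A rise of moderate size, beyond the scatter, is expected for compound 4 in this assay, with room on either side. Compound 4 is expected near 20000 nM, between 6000 nM and 65000 nM. The step expected from this change is a 2.1-fold higher number from compound 1 to compound 4 (0.32 log units; beyond the scatter).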

Compound 4, concentration for 50% growth inhibition: 15800 nM
Compound 4: the middle estimate sits 1.3-fold (0.10 log units) above what was measured; low and high end bracket the measured number.
By their numbers in this assay, from the lowest: compound 3; then compounds 1 and 4 (each within the scatter of the next). At a limit, above all of these: compound 2.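

In this assay this position now has its first direct pair, which gives a 1.6-fold higher number from compound 1 to compound 4 (0.22 log units; within the scatter) and so does not separate methylsulfanyl from the selenium-bearing group on the core of compound 1. Selenium at this carbon is therefore not shown to be required for the growth inhibition seen with compound 1. Nothing measured here bears on what lies behind this result.

As far as these compounds go, whether the same exchange reads alike on the core of compound 3 stays open. So does the effect of a longer chain or an amine on this carbon.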